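Swapping a trihydroxyphenyl for a hydroxy-methoxyphenyl

A few compounds are considered here, and "the series" means these few. Any claim that something is new, unique, unknown or untested is made for them only; others in the source may bear on it.

Of the compounds shown here, three sharing one core have been tested in an ADME assay on THP-1 cells (Homo sapiens) for cytotoxicity; a higher number here means a weaker inhibitor, a lower number a stronger inhibitor. Compound 1 `COc1ccccc1-c1nnc(-c2ccc(C(=O)N/N=C/c3ccc(O)c(O)c3)cc2)o1` gives 100000 nM. Compound 2 `COc1ccccc1-c1nnc(-c2ccc(C(=O)N/N=C/c3cccnc3)cc2)o1` gives 167000 nM. Compound 3 `COc1ccccc1-c1nnc(-c2ccc(C(=O)N/N=C/c3c(O)cc(O)cc3O)cc2)o1` gives 12400 nM, the lowest of the three, and it sits apart from the others: an 8.1-fold lower number from compound 1 to compound 3 (0.91 log units; beyond the scatter), while a 13-fold lower number from compound 2 to compound 3 (1.13 log units; beyond the scatter). Between the first two the difference is small, as a 1.7-fold higher number from compound 1 to compound 2 (0.22 log units; within the scatter).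

Compound 4 `COc1ccc(O)c(/C=N/NC(=O)c2ccc(-c3nnc(-c4ccccc4OC)o3)cc2)c1` is not yet measured. It differs from compound 3 in one place: 2-hydroxy-5-methoxyphenyl in place of 2,4,6-trihydroxyphenyl on a carbon with a double bond to nitrogen. Among the compounds with values here, the only step that touches this part of the molecule in a comparable way is the one from compound 1 to compound 3, where adding hydroxyl groups on that ring went with a modest fall in the number. Compound 4 moves the other way, keeping a single hydroxyl and exchanging the rest for a methoxy group, so the number is expected to rise again, though by how much is uncertain. The expected change is a 4.8-fold higher number from compound 3 to compound 4 (0.68 log units; beyond the scatter) for compound 4. In this assay compound 4 is therefore estimated at 60000 nM, with a likely range from 20000 nM to 160000 nM.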

Compound 4, half-maximal inhibitory concentration: 303000 nM
For compound 4 the middle estimate is 5.1-fold (0.70 log units) below the measured one, outside the stated range (above it).
By their numbers in this assay, from the lowest: compound 3; then compounds 1, 2 and 4 (each within the scatter of the next, the first and the last beyond it).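

In this assay, the swap to 2-hydroxy-5-methoxyphenyl keeps the heavy-atom count of 2,4,6-trihydroxyphenyl and one hydroxyl on the ring, yet it gives a 24-fold higher number from compound 3 to compound 4 (1.39 log units; beyond the scatter), so a ring of the same size with a hydroxyl on it does not preserve the low number of compound 3. Compound 4 also shows a 3.0-fold higher number from compound 1 to compound 4 (0.48 log units; beyond the scatter), while a 1.8-fold higher number from compound 2 to compound 4 (0.26 log units; within the scatter) leaves it not separable from compound 2, which carries pyridin-3-yl at this position and no hydroxyl at all. Among these four compounds, the low number therefore belongs to compound 3 alone, and the other three rings do not bring it back.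

No measurement shown here explains why this one ring stands apart. On these data alone, it also stays open whether the number of hydroxyl groups, their placement or the presence of a methoxy group matters most, and whether a phenyl ring carrying an amine or a carboxylic acid on this carbon would give a low number like that of compound 3.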